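Chloro in place of difluoromethoxy: compound 2 to compound 4

A few compounds are considered here, and "the series" means these few. Any claim that something is new, unique, unknown or untested is made for them only; others in the source may bear on it.

Of the compounds shown here, three on a shared core have numbers so far. In a physicochemical assay for lipophilicity, at pH 7.4 (a higher number here means a more lipophilic compound, a lower number a more polar compound), compound 1 (`COCc1ccccc1C1Cc2nccn2C1`) gives 1.8. In the same measurement compound 2 (`FC(F)Oc1ccccc1C1Cc2nccn2C1`) gives 2.3 and compound 3 (`COc1cccc(C2Cc3nccn3C2)c1`) gives 2, two values within the scatter of each other. Compound 2 thus stands apart from compound 1 but not from compound 3. Among the measured compounds shown here, the one measured step in the set is a number 0.50 log units higher from compound 1 to compound 2 (beyond the scatter), modest and beyond the scatter.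

The next change leads to compound 4 (`Clc1ccccc1C1Cc2nccn2C1`), not yet measured: chloro in place of difluoromethoxy on an aromatic carbon. The measured step bears on this only in part. For the measured compounds named here, it also exchanges a group on an aromatic carbon and has difluoromethoxy on one side, but no measured compound carries chloro, and nothing measured gives a direction. Its modest size serves as a rough guide to how far such an exchange can move the number in this assay. The anchor is therefore compound 2 at 2.3. The expected change is none beyond the scatter, with an estimated step of a number 0.10 log units lower from compound 2 to compound 4 (within the scatter). For compound 4 the estimated value is 2.2, with an expected range from 1.8 to 2.6.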

Compound 4, distribution coefficient: 2.6
The estimate for compound 4 lay 0.40 log units below the measured number; the measured number falls inside the stated range.
By their numbers in this assay, from the lowest: compounds 1, 3, 2 and 4 (each within the scatter of the next, the first and the last beyond it).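

At this aromatic carbon, chloro with 1 heavy atom and difluoromethoxy with 4 heavy atoms are not separated in this assay: the exchange gives a number 0.30 log units higher from compound 2 to compound 4 (within the scatter), so the loss of the oxygen and both fluorines leaves no readable change in this measurement. Methoxymethyl is now set apart from two different groups at the same place, with a number 0.50 log units higher from compound 1 to compound 2 (beyond the scatter) alongside a number 0.80 log units higher from compound 1 to compound 4 (beyond the scatter), and this holds for both compound 2 and compound 4 with no compound at this place going against it. No measured data at hand account for either step, which therefore stand as description only.

As far as these compounds go, the series shows only neutral groups at this aromatic carbon, so it remains open whether an amine or a carboxylic acid there would fall anywhere near the band of compound 2 and compound 4 in this assay. Also open, from the compounds shown here alone, is whether a single-atom fluoro or a nitrile would stay with chloro or move towards methoxymethyl, and whether chloro would behave the same way at any other carbon of this ring.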